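This account rests on a few compounds, and the source may have more. Where it says the series, first, only, none or still open, it means among the compounds named here.

In an ADME assay on HEK293 cells (Homo sapiens) for cytotoxicity, read by MTT assay, with a stated time of 48 h (on this read-out higher numbers stand for weaker inhibition and lower numbers for stronger inhibition), compounds sharing one core differ only in the chain on an aromatic nitrogen. Compound 1 `CCn1c(N)c(-c2nc3ccccc3[nH]2)c2nc(C#N)c(C#N)nc21` gives > 50000 nM, which is a limit of the assay and not a number. Compound 3 `CCCn1c(N)c(-c2nc3ccccc3[nH]2)c2nc(C#N)c(C#N)nc21` gives > 50000 nM, also a limit. That places compound 3 at the limit of > 50000 nM in this assay, at which 2 of the 3 values shown sit. For the measured compounds named here, compound 2 `N#Cc1nc2c(-c3nc4ccccc4[nH]3)c(N)n(CCN3CCCC3)c2nc1C#N` is the only one with a true number, 18300 nM.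

Compound 4 `N#Cc1nc2c(-c3nc4ccccc4[nH]3)c(N)n(CCO)c2nc1C#N` has hydroxy in place of methyl on a saturated chain carbon, two bonds along the chain from an aromatic nitrogen, so propyl becomes 2-hydroxyethyl: hydroxy in place of methyl on a saturated chain carbon, two bonds along the chain from an aromatic nitrogen.

Three measured steps act at this same place. The methyl step, a step that the two limits leave unreadable from compound 1 to compound 3, cannot be sized. The two readable steps, an at least 2.7-fold lower number from compound 1 to compound 2 (0.43 log units; beyond the scatter) and an at least 2.7-fold higher number from compound 2 to compound 3 (0.43 log units; beyond the scatter), both involve pyrrolidin-1-yl, which compound 4 lacks. No step beyond the scatter is therefore expected, and a further limit is the likeliest result. The expected change is a number no higher from compound 3 to compound 4 (the limit leaves the size open). Compound 4 is estimated at 50000 nM, with an expected range of 20000 nM to 100000 nM.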

Compound 4, half-maximal inhibitory concentration: > 50000 nM
Compound 4: no number, only a limit; the forecaster's own chance of this, stated with the estimate: 65%; the middle value lies on the limit itself.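

In this assay compound 4 gives > 50000 nM, which is a limit of the assay and not a number. Hydroxy in place of methyl therefore does not bring this chain off the limit, although the steps from compound 1 and compound 3 to compound 4 cannot be read, while hydroxy in place of pyrrolidin-1-yl gives an at least 2.7-fold higher number from compound 2 to compound 4 (0.43 log units; beyond the scatter). Among the chains shown on this nitrogen, only the pyrrolidin-1-yl chain of compound 2 gives a true number, and the others stay at the limit: the limit of > 50000 nM in this assay, at which 3 of the 4 values shown sit.

Going by these compounds, how far compound 1, compound 3 and compound 4 differ from one another stays open, as none of them has a true number. Also open, on these data alone, is how a chain ending in a dimethylamino group or a morpholine ring would read, and whether a longer plain alkyl chain would stay at the limit.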